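3-Hydroxypiperidin-1-yl in place of morpholin-4-yl

The compounds below may be only part of what the source reports. "The series", "measured", "known", "first", "only" and "open" are said of these compounds alone.

In an ADME assay on microsomes from liver (Homo sapiens) for pharmacokinetics, read by LC-MS, with a stated time of 60 min, tested at 1 uM (on this read-out lower numbers stand for slow clearance and higher numbers for fast clearance), compound 1 (`O=C(NCc1ccc(S(=O)(=O)C2CCC(F)(F)CC2)cc1)N1Cc2ccncc2C1`) gives 6 mL/min/kg and compound 2 (`O=C(NCc1ccc(S(=O)(=O)N2CCOCC2)cc1)N1Cc2ccncc2C1`) gives 9 mL/min/kg with no separation between them. Going by the values given here, the one measured step (a 1.5-fold higher number from compound 1 to compound 2 (0.18 log units; within the scatter)) also changes the group on the sulfonyl sulfur and lies within the scatter, so compound 2 stands level with compound 1. Compound 3 (`O=C(NCc1ccc(S(=O)(=O)N2CCC[C@H](O)C2)cc1)N1Cc2ccncc2C1`) carries 3-hydroxypiperidin-1-yl in place of morpholin-4-yl on a sulfonyl sulfur. Among the compounds with values here, no measured compound carries a hydroxy group, so the data give no direction, and no step beyond the scatter is expected in this assay here. The expected step (a 1.1-fold higher number from compound 2 to compound 3 (0.05 log units; within the scatter)) is correspondingly small. The estimate for compound 3 is 10 mL/min/kg (range 5 mL/min/kg to 20 mL/min/kg).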

Compound 3, clearance: 8 mL/min/kg
For compound 3 the middle estimate is 1.3-fold (0.10 log units) above the measured one; the measured number falls inside the stated range.
By their numbers in this assay, from the lowest: compounds 1, 3 and 2 (each within the scatter of the next).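

At the sulfonyl sulfur, the hydroxy group of 3-hydroxypiperidin-1-yl adds a hydrogen-bond donor absent from morpholin-4-yl, and this assay shows a 1.1-fold lower number from compound 2 to compound 3 (0.05 log units; within the scatter) for this change. Measured against 4,4-difluorocyclohexyl, the same group shows a 1.3-fold higher number from compound 1 to compound 3 (0.12 log units; within the scatter) and so stands level with both earlier groups at this position. No available evidence bears on this result.

Still open, going by these compounds, is whether piperazin-1-yl, a carboxylic acid on the ring or an open-chain dimethylamino group would stay level at this position. The opposite stereoisomer of 3-hydroxypiperidin-1-yl is also unresolved.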